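A Heteroaryl Swap on an Inactive Tertiary Amine

The source may hold more compounds than are shown below. What is called first, only, known or untested is meant among the compounds shown, and "the series" means these compounds.

Compound 1 `Clc1ccc(CN(Cc2cccnc2)Cc2nccs2)cc1` was examined in an assay on isolated protein for agonist activity at nuclear receptor subfamily 1 group D member 1 (Homo sapiens), read by FRET, with a stated time of 1 h (on this read-out lower numbers stand for an effect already at smaller amounts and higher numbers for an effect only at larger amounts of compound), where compound 1 returns only an assay limit, > 50000 nM. That limit is recorded as the limit of > 50000 nM in this assay, at which 1 of the 2 values shown sits. Compound 2 `O=[N+]([O-])c1ccc(CN(Cc2ccc(Cl)cc2)Cc2ccccc2F)s1`, built on a different core, gives 63 nM in this assay. Compound 3 `Clc1ccc(CN(Cc2cccnc2)Cc2ncc[nH]2)cc1` differs from compound 1 by 1H-imidazol-2-yl in place of 1,3-thiazol-2-yl on a saturated chain carbon bound to an amine nitrogen. Among the compounds with values here, no measured step of this kind exists, so the expected step is a step that the limit leaves unreadable from compound 1 to compound 3, nothing beyond the scatter. Compound 3 is accordingly estimated at 60000 nM, within 20000 nM to 300000 nM, most likely again as a limit.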

Compound 3, half-maximal effective concentration: > 50000 nM
Compound 3 was reported as a limit; the forecaster's own chance of this, stated with the estimate: 80%; the middle value is on the limit's open side.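

No step can be read from compound 1 to compound 3, since both return only an assay limit: the limit of > 50000 nM in this assay, at which 2 of the 3 values shown sit.

The compounds shown leave open whether 1H-imidazol-2-yl and 1,3-thiazol-2-yl differ at all in their effect on this tertiary amine.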